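Chloro to Nitro on the Pendant Phenyl Ring

This account rests on a few compounds, and the source may have more. Where it says the series, first, only, none or still open, it means among the compounds named here.

Three measured compounds share one core and differ only in the aryl group attached to it. Compound 1 `COc1ccccc1-c1ccc2ncn(-c3cc(OC)c(OC)c(OC)c3)c2c1` carries a 2-methoxyphenyl, and in a functional assay on MCF7 cells (Homo sapiens) for antiproliferative activity, read by MTT assay, with a stated time of 72 h (a higher number here means a weaker inhibitor, a lower number a stronger inhibitor), compound 1 gives 1750 nM. Compound 2 `COc1cc(-n2cnc3ccc(-c4cc(F)ccc4F)cc32)cc(OC)c1OC` carries a 2,5-difluorophenyl; in this assay compound 2 gives 6420 nM, so a 3.7-fold higher number from compound 1 to compound 2 (0.56 log units; beyond the scatter). Compound 3 `COc1cc(-n2cnc3ccc(-c4cccc(Cl)c4)cc32)cc(OC)c1OC` carries a 3-chlorophenyl; in this assay compound 3 gives 3120 nM. Here a 1.8-fold higher number from compound 1 to compound 3 (0.25 log units; within the scatter), while a 2.1-fold lower number from compound 2 to compound 3 (0.31 log units; beyond the scatter). Compound 3 thus stands second highest of the three numbers, close to compound 1 and somewhat apart from compound 2.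

Going by the values given here, compound 4 `COc1cc(-n2cnc3ccc(-c4cccc([N+](=O)[O-])c4)cc32)cc(OC)c1OC` has not yet been measured. nitro in place of chloro on an aromatic carbon No measured step exchanges a single group on the pendant phenyl ring for another while the rest stays the same; the steps that bear on it are the three exchanges of the whole aryl group, which were modest at most and in one case within the scatter. A step of similar size or none beyond the scatter is therefore expected, a 1.1-fold higher number from compound 3 to compound 4 (0.05 log units; within the scatter). Compound 4 is estimated at 3500 nM, with a range from 1200 nM to 10000 nM.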

Compound 4, half-maximal inhibitory concentration: 4560 nM
Compound 4: the middle estimate sits 1.3-fold (0.11 log units) below what was measured; low and high end bracket the measured number.
By their numbers in this assay, from the lowest: compounds 1, 3, 4 and 2 (each within the scatter of the next, the first and the last beyond it).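

Going by these compounds alone, replacing chloro with nitro on this aromatic carbon, meta to a large group, is the first exchange of a single group on the pendant phenyl ring, and in this assay it leaves (a 1.5-fold higher number from compound 3 to compound 4 (0.16 log units; within the scatter)), so at this place a nitro reads no differently from a chloro, although it brings hydrogen-bond acceptors that chloro lacks. Set against the other aryl groups, the 3-nitrophenyl compound gives (a 1.4-fold lower number from compound 2 to compound 4 (0.15 log units; within the scatter)), which does not separate it from the 2,5-difluorophenyl compound, but (a 2.6-fold higher number from compound 1 to compound 4 (0.42 log units; beyond the scatter)), which leaves the 2-methoxyphenyl compound with the lower number by a modest margin. No accompanying measurement bears on why these numbers fall as they do.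

Going by these compounds, whether an amine or a carboxylic acid at this same place would also stay within the scatter of compound 3 remains open. Also open, on these data alone, is how much of the gap from compound 1 comes from the identity of the group and how much from where it sits on the ring, as the 2-methoxyphenyl and 3-nitrophenyl groups differ in both.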